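The compounds below may be only part of what the source reports. "The series", "measured", "known", "first", "only" and "open" are said of these compounds alone.

Measured so far in a functional assay on HeLa cells (Homo sapiens) for inhibition, read by CCK-8 assay, with a stated time of 48 h (on this read-out higher numbers stand for weaker inhibition and lower numbers for stronger inhibition), are two compounds:
Compound 1 `COc1ccc(Oc2ccc(C(C)C)cc2-c2ccsc2S(=O)(=O)NCCNC(=S)Nc2ccc([N+](=O)[O-])cc2)cc1OC` gives 11900 nM
Compound 2 `O=S(=O)(NCCNC(=S)Nc1cc(C(F)(F)F)cc(C(F)(F)F)c1)c1ccc(-c2ccccc2OCc2cccc(O)c2)s1` gives 14900 nM

Compound 2 at 14900 nM lies within the usual scatter of compound 1 at 11900 nM and the two cannot be told apart on these numbers. Compound 3 `O=S(=O)(NCCNC(=S)Nc1cc(C(F)(F)F)cc(C(F)(F)F)c1)c1ccc(-c2ccccc2O[C@H]2CC[C@@H](O)CC2)s1` departs from compound 2 in one place, on an oxygen on an aromatic ring, where 4-hydroxycyclohexyl stands in place of 3-hydroxybenzyl. The change is counted as 4-hydroxycyclohexyl in place of 3-hydroxybenzyl on an oxygen on an aromatic ring and the rest of the molecule stays the same. For the measured compounds named here, no measured pair shows this kind of change in this assay and the data offer no direction for it. No shift beyond the scatter is therefore expected, and the estimated move is a 1.1-fold lower number from compound 2 to compound 3 (0.06 log units; within the scatter) with no weight placed on its sign. In this assay compound 3 is estimated at 13000 nM with 5000 nM to 35000 nM as the expected range.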

Compound 3, half-maximal inhibitory concentration: 10900 nM
Estimate against measurement, compound 3: 1.2-fold (0.08 log units) above, and the stated range covers the measured number.
By their numbers in this assay, from the lowest: compounds 3, 1 and 2 (each within the scatter of the next).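

In this assay, for the compounds shown here, replacing 3-hydroxybenzyl with 4-hydroxycyclohexyl on an oxygen on an aromatic ring gives a 1.4-fold lower number from compound 2 to compound 3 (0.14 log units; within the scatter), the first comparison here between compounds that differ in one place. At this position, then, a six-membered aromatic ring of carbon only can give way to a non-aromatic one bearing two defined stereocentres without a shift beyond the scatter, although this single pair says nothing about other replacements. No available evidence bears on this result.

Both groups carry a hydroxy group, so the compounds shown leave open whether plain cyclohexyl or unsubstituted benzyl would fall within the same scatter, or whether an amine or a carboxylic acid in place of that hydroxy group would shift the number. They also leave open how the other stereoisomer of 4-hydroxycyclohexyl would read in this assay.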